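The source may report more compounds than this note shows. Statements on the series, on what has been measured and on what is new or still open speak of the compounds shown alone.

Three amides have been measured in an ADME assay on microsomes from liver (Mus musculus) for metabolic stability, read by LC-MS, with a stated time of 30 min, tested at 1 uM; on this read-out higher numbers stand for a more stable compound and lower numbers for a less stable compound. Compound 1 (`O=C(NCc1ccc(S(=O)(=O)c2ccccc2)cc1)c1ccc2nccn2c1`) gives 18%, compound 2 (`O=C(NCc1ccc(S(=O)(=O)c2cccc(C(F)(F)F)c2)cc1)c1cc2ccncc2o1`) gives 64% and compound 3 (`O=C(NCc1ccc(S(=O)(=O)c2cccc(C(F)(F)F)c2)cc1)c1cnc2nccn2c1`) gives 27%. Compound 3 thus lies within the scatter of compound 1 and well short of compound 2. Going by the values given here, the one measured step, a number 37 percentage points lower from compound 2 to compound 3 (beyond the scatter), is large and beyond the scatter, and it was made on a carbonyl carbon, the place that changes again now.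

Compound 4 (`O=C(NCc1ccc(S(=O)(=O)c2cccc(C(F)(F)F)c2)cc1)c1ccc2nccn2c1`) differs from compound 3 only in that group: a group of 9 heavy atoms (7 carbon, 2 nitrogen; one five-membered aromatic ring with 2 hetero atoms, one six-membered aromatic ring with 1 hetero atom) in place of a group of 9 heavy atoms (6 carbon, 3 nitrogen; one five-membered aromatic ring with 2 hetero atoms, one six-membered aromatic ring with 2 hetero atoms), on a carbonyl carbon. The measured step shows that a change at this place can move the number a long way, but that step alone does not show what this exchange will do. The entering group also stands in compound 1, which lacks the trifluoromethyl group and gives 18%, a value within the scatter of compound 3. On that basis, no shift beyond the scatter is expected in this assay. The estimate is a number 2 percentage points lower from compound 3 to compound 4 (within the scatter). Compound 4 is expected at 25%, with an estimated range from 12% to 42%.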

Compound 4, percent of the compound remaining: 17%
Compound 4: middle estimate off by 8 percentage points, on the high side; the measured number falls inside the stated range.
By their numbers in this assay, from the lowest: compounds 4, 1 and 3 (each within the scatter of the next); then compound 2.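

In this assay, the exchange of one ring group for the other on the carbonyl carbon comes to a number 10 percentage points lower from compound 3 to compound 4 (within the scatter), so this read-out does not separate these two groups on the shared core. Going by these compounds alone, the first reading of trifluoromethyl in place of hydrogen on an aromatic carbon, with the group on the carbonyl carbon held the same, is a number 1 percentage points lower from compound 1 to compound 4 (within the scatter), and this pair is not separated either. Set against the group of compound 2, the entering group gives a number 47 percentage points lower from compound 2 to compound 4 (beyond the scatter), which matches the size class of a number 37 percentage points lower from compound 2 to compound 3 (beyond the scatter), so among compounds 2, 3 and 4 the large gap at this position belongs to the group of compound 2 alone.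

No measurement shown here accounts for that gap. The compounds leave open whether trifluoromethyl in place of hydrogen would also stay within the scatter with the group of compound 2 on the carbonyl carbon, and what a methoxy group on that same aromatic carbon would do.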